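Replacing the side chain of compound 2

This account rests on a few compounds, and the source may have more. Where it says the series, first, only, none or still open, it means among the compounds named here.

In an ADME assay on microsomes from liver (Homo sapiens) for metabolic stability, using NADPH, with a stated time of 60 min, in the presence of a further agent that is not named here (on this read-out higher numbers stand for fast clearance and lower numbers for slow clearance), compound 1 `O=C(O)COc1ccc([C@H]2CC[C@]3(CC2)OOC2(O3)C3CC4CC2CC(C3)C4O)cc1` gives < 7 mL.min-1.g-1, which is a limit and not a number. Compound 2 `O=C(O)CNC(=O)COc1ccc([C@H]2CC[C@]3(CC2)OOC2(O3)C3CC4CC(C3)CC2C4)cc1` likewise gives only a limit, < 7 mL.min-1.g-1. The evidence so far is therefore (the limit of < 7 mL.min-1.g-1 in this assay, at which 2 of the 2 values shown sit). Compound 3 `O=C(O)CN1CCC(Oc2ccc([C@H]3CC[C@]4(CC3)OOC3(O4)C4CC5CC(C4)CC3C5)cc2)CC1` differs on an oxygen on an aromatic ring, where 1-(carboxymethyl)piperidin-4-yl stands in place of ((carboxymethyl)carbamoyl)methyl (1-(carboxymethyl)piperidin-4-yl in place of ((carboxymethyl)carbamoyl)methyl on an oxygen on an aromatic ring). Among the measured compounds shown here, no measured step bears on this change, and a shift within the usual scatter is expected: the estimated step is a step that the limit leaves unreadable from compound 2 to compound 3. Compound 3 is estimated at 6 mL.min-1.g-1, with an expected range of 3 mL.min-1.g-1 to 14 mL.min-1.g-1.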

Compound 3, intrinsic clearance in microsomes: < 7 mL.min-1.g-1
Compound 3 gave a limit, no number; the forecaster's own chance of this, stated with the estimate: 65%; the middle value lies beyond the limit too.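

In this assay, among the compounds shown here, compound 2 and compound 3 both give only a limit, so no step between them can be read. The compounds shown leave open whether this change of side chain alters clearance at all.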